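The source may report more compounds than this note shows. Statements on the series, on what has been measured and on what is new or still open speak of the compounds shown alone.

Compound 1 `CCN(CC)c1ccc2cc(C(=O)c3ccc(N4CCN(C(=O)CN5CCN(S(=O)(=O)c6ccc(C#N)cc6)CC5)CC4)cc3)oc2c1` gives > 40000 nM in a functional assay on MCF7 cells (Homo sapiens) for cytotoxicity, read by MTT assay, with a stated time of 48 h; a higher number here means a weaker inhibitor, a lower number a stronger inhibitor. Compound 2 `CCN(CC)c1ccc2cc(C(=O)c3ccc(N4CCN(C(=O)CN5CCN(S(=O)(=O)c6ccc(F)cc6)CC5)CC4)cc3)oc2c1` gives 20500 nM. Compound 3 `C#CCN1CCN(CC(=O)N2CCN(c3ccc(C(=O)c4cc5ccc(N(CC)CC)cc5o4)cc3)CC2)CC1` gives > 40000 nM.

For compound 1 the reported value is a limit of the assay, not a number. For compound 3 it is likewise a limit, not a number. Compound 3 thus stands at the limit of > 40000 nM in this assay, at which 2 of the 3 values shown sit, and only compound 2 gives a read number. Moving from compound 1 to compound 3 gives a step that the two limits leave unreadable from compound 1 to compound 3, and from compound 2 to compound 3 the data show an at least 1.9-fold higher number from compound 2 to compound 3 (0.29 log units; that floor lies within the scatter).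

Compound 4 `CCN(CC)c1ccc2cc(C(=O)c3ccc(N4CCN(C(=O)CN5CCN(CC(C)=O)CC5)CC4)cc3)oc2c1` differs from compound 3 by acetyl in place of ethynyl on a saturated chain carbon bound to an amine nitrogen in a ring. For the measured compounds named here, no measured step touches this part of the molecule: the measured steps exchange an arylsulfonyl group for propargyl, or exchange the substituent on that aryl ring, as in an at least 1.9-fold lower number from compound 1 to compound 2 (0.29 log units; that floor lies within the scatter). So nothing measured here reads directly on the new change. Compound 3 sits at a limit, and compound 4 is expected to stay near it, with an expected step that the limit leaves unreadable from compound 3 to compound 4. The estimate for compound 4 is 45000 nM, with a range from 15000 nM to 150000 nM.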

Compound 4, half-maximal inhibitory concentration: 11000 nM
For compound 4 the middle estimate is 4.1-fold (0.61 log units) above the measured one; measured number below the stated range.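

In this assay, for the compounds shown here, acetyl in place of ethynyl on a saturated chain carbon bound to an amine nitrogen in a ring gives an at least 3.6-fold lower number from compound 3 to compound 4 (0.56 log units; beyond the scatter), the first step at this end of the molecule that clearly exceeds the scatter. The 2-oxopropyl group in place of (4-cyanophenyl)sulfonyl gives an at least 3.6-fold lower number from compound 1 to compound 4 (0.56 log units; beyond the scatter), whereas in place of (4-fluorophenyl)sulfonyl it gives a 1.9-fold lower number from compound 2 to compound 4 (0.27 log units; within the scatter), so this group and the (4-fluorophenyl)sulfonyl group cannot be told apart here. Both larger steps start from a limit of the assay, so only their floors are known: the limit of > 40000 nM in this assay, at which 2 of the 4 values shown sit.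

From the compounds shown here alone, whether the carbonyl itself carries the step remains open, and a plain propyl chain or a 2-hydroxypropyl group on this nitrogen would address that. Going by these compounds, how a carboxylic acid or a longer chain ending in a carbonyl would read at this place also remains open.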